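The source may hold more compounds than are shown below. What is called first, only, known or untested is meant among the compounds shown, and "the series" means these compounds.

Measured compounds in a functional assay on BT-549 cells (Homo sapiens) for inhibition; on this read-out lower numbers stand for stronger inhibition of growth and higher numbers for weaker inhibition of growth:
compound 1 `COc1cc(/C=C/C(=O)c2cccc(-n3cc(-c4ccccc4)[nH]c3=O)c2)ccc1O` gives 2780 nM
compound 2 `O=C(/C=C/c1cccc(O)c1)c1cccc(-n2cc(-c3ccc(Cl)cc3)[nH]c2=O)c1` gives 1450 nM
compound 3 `COc1ccc(-c2cn(-c3cccc(C(=O)/C=C/c4ccc(O)c(OC)c4)c3)c(=O)[nH]2)cc1` gives 4570 nM

Going by the values given here, compound 3 sits at the top of these three numbers, but its distance to compound 1 is within the scatter: the one step available, a 1.6-fold higher number from compound 1 to compound 3 (0.22 log units; within the scatter), is not a real shift. Only compound 2 lies clearly apart from compound 3, with a number beyond the scatter below it.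

Compound 4 `COc1cc(/C=C/C(=O)c2cccc(-n3cc(-c4ccc(Cl)cc4)[nH]c3=O)c2)ccc1O` has not been measured in this assay. It differs from compound 3 by one change: chloro in place of methoxy on an aromatic carbon. Among the compounds with values here, no measured pair shows chloro against methoxy at this position alone. Compound 2 carries the same chloro group, but also lacks the methoxy on the other aromatic ring, so its value gives only indirect support. The hydrogen-to-methoxy step from compound 1 to compound 3 was within the scatter, which says little about what chloro does here.

With that thin basis, the expectation for compound 4 is a modest move toward compound 2, a 2.3-fold lower number from compound 3 to compound 4 (0.36 log units; beyond the scatter), and compound 4 is estimated at 2000 nM with a range from 900 nM to 4500 nM.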

Compound 4, concentration for 50% growth inhibition: 2520 nM
For compound 4 the middle estimate is 1.3-fold (0.10 log units) below the measured one; measured number inside the range.
By their numbers in this assay, from the lowest: compounds 2, 4, 1 and 3 (each within the scatter of the next, the first and the last beyond it).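

In this assay, the change from 4-methoxyphenyl to 4-chlorophenyl now has a direct reading: a 1.8-fold lower number from compound 3 to compound 4 (0.26 log units; within the scatter), and the comparison with hydrogen at the same place gives a 1.1-fold lower number from compound 1 to compound 4 (0.04 log units; within the scatter), so neither step separates chloro from the other two groups at this position. With chloro held in place, the change on the other aromatic ring also stays small, with a 1.7-fold higher number from compound 2 to compound 4 (0.24 log units; within the scatter), so 4-hydroxy-3-methoxyphenyl and 3-hydroxyphenyl are not told apart in this chloro-bearing pair. Compound 4 therefore lies within the scatter of all three earlier compounds, and none of its single-place steps reaches beyond the scatter.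

No supporting data are available to explain these small steps. Going by these compounds, whether an amine or a carboxylic acid at this position of the aromatic ring, or a longer chain in place of the methoxy group, would give a step beyond the scatter remains open.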